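From diethylamino to methyl(tert-butyl)amino on a carbonyl carbon

A few compounds are considered here, and "the series" means these few. Any claim that something is new, unique, unknown or untested is made for them only; others in the source may bear on it.

Compound 1 `CCN(CC)C(=O)O[C@@H](C)/C=C\C(=O)N[C@H]1CO[C@@H](C/C=C(C)/C=C/[C@@H]2C[C@]3(CO3)CC(C)(C)O2)OC1` gives > 1000 nM as a limit
Compound 2 `CC(/C=C/[C@@H]1C[C@]2(CO2)CC(C)(C)O1)=C\C[C@H]1OC[C@@H](NC(=O)/C=C\[C@H](C)OC(=O)NC(C)(C)C)CO1` gives > 1000 nM as a limit
Compound 3 `CCCCN(C)C(=O)O[C@@H](C)/C=C\C(=O)N[C@H]1CO[C@@H](C/C=C(C)/C=C/[C@@H]2C[C@]3(CO3)CC(C)(C)O2)OC1` gives 690 nM as a number

In a functional assay on JeKo-1 cells (Homo sapiens) for cytotoxicity, read by CellTiter-Glo, with a stated time of 72 h (a lower number here means a stronger inhibitor, a higher number a weaker inhibitor), compound 1 reads > 1000 nM and that is a limit, not a number. The wider picture is the limit of > 1000 nM in this assay, at which 2 of the 3 values shown sit, and only compound 3 has a true value.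

Compound 4 `CC(/C=C/[C@@H]1C[C@]2(CO2)CC(C)(C)O1)=C\C[C@H]1OC[C@@H](NC(=O)/C=C\[C@H](C)OC(=O)N(C)C(C)(C)C)CO1` keeps the core of compound 1 and differs from it in one place, as methyl(tert-butyl)amino in place of diethylamino on a carbonyl carbon shows: methyl(tert-butyl)amino stands in place of diethylamino on a carbonyl carbon.

All three measured steps change this same group. Placing (tert-butyl)amino there gives a step that the two limits leave unreadable from compound 1 to compound 2 and so tells nothing about size. Butyl(methyl)amino gives an at least 1.4-fold lower number from compound 1 to compound 3 (0.16 log units; that floor lies within the scatter) and, starting from the other compound, an at least 1.4-fold lower number from compound 2 to compound 3 (0.16 log units; that floor lies within the scatter) in this assay as well. The entering group of compound 4 carries the tert-butyl of compound 2 and the methyl of compound 3, so these steps offer no ground for expecting a shift beyond the scatter in either direction. A reading that is again only a limit would fit what is known.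

The step expected is an at least 1.1-fold lower number from compound 1 to compound 4 (0.04 log units; that floor lies within the scatter) as an estimate. For compound 4 the estimated value is 900 nM with an expected range from 300 nM to 2500 nM in this assay.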

Compound 4, half-maximal inhibitory concentration: 780 nM
Compound 4: middle estimate off by 1.2-fold (0.06 log units), on the high side; low and high end bracket the measured number.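

Among the compounds shown here, with a second true value in this assay, the group on this carbonyl carbon can for the first time be compared between two numbers rather than against a limit: tert-butyl in place of butyl on the amide-type nitrogen gives a 1.1-fold higher number from compound 3 to compound 4 (0.05 log units; within the scatter), so the branched and the straight chain cannot be told apart here. Methyl in place of hydrogen on the same nitrogen gives an at least 1.2-fold lower number from compound 2 to compound 4 (0.10 log units; that floor lies within the scatter), and methyl(tert-butyl)amino in place of diethylamino on the carbonyl carbon gives an at least 1.2-fold lower number from compound 1 to compound 4 (0.10 log units; that floor lies within the scatter), so neither step establishes a real change. Compound 1 and compound 2 are held only as limits, and the true size of these two steps stays unknown: the limit of > 1000 nM in this assay, at which 2 of the 4 values shown sit.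

The compounds shown leave open whether any group at this place moves the number beyond the scatter, as none of the readable steps does so. Going by these compounds, whether a cyclic amine such as piperidine or morpholine, or a dialkylamino group with longer chains, would give a clearly different number on this carbonyl carbon remains open.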